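Microsomal stability notes: piperidinyl to carbamoylpiperazinylmethyl

The compounds below may be only part of what the source reports. "The series", "measured", "known", "first", "only" and "open" are said of these compounds alone.

Measured compounds:
- compound 1 `c1ccc2c(c1)CN[C@@H](CN(CC[C@H]1CCCNC1)[C@H]1CCCc3cccnc31)C2`: 55%
- compound 2 `c1cnc(CN(CCCN2CCNCC2)[C@H]2CCCc3cccnc32)nc1`: 68%
- compound 3 `c1cnc2c(c1)CCC[C@@H]2N(CCCN1CCNCC1)Cc1nc2ccccc2[nH]1`: 29%

In an ADME assay on microsomes from liver (Rattus norvegicus) for metabolic stability, read by LC-MS, with a stated time of 10 min, tested at 0.5 uM (on this read-out higher numbers stand for a more stable compound and lower numbers for a less stable compound), compound 1 stands second highest of the three numbers. Compound 2 is its nearest neighbour, higher by a margin beyond the scatter, and compound 3 is furthest, lower by a margin beyond the scatter.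

Going by the values given here, the one measured step in the set is a number 39 percentage points lower from compound 2 to compound 3 (beyond the scatter), a change of 1H-benzimidazol-2-yl in place of pyrimidin-2-yl on a saturated chain carbon bound to an amine nitrogen. It involves aromatic groups at a different position from the change considered here and so gives no direct guide.

Compound 4 `NC(=O)N1CCN(CCCN(C[C@H]2Cc3ccccc3CN2)[C@H]2CCCc3cccnc32)CC1` differs from compound 1 by (4-carbamoylpiperazin-1-yl)methyl in place of piperidin-3-yl on a saturated chain carbon, two bonds along the chain from an amine nitrogen. Among the compounds with values here, no measured pair in this assay covers a change of this kind, and the shared core of compound 1 is kept. With nothing to point either way, the expected step of no change at the digits printed from compound 1 to compound 4 (within the scatter) is one that stays within the scatter, direction undetermined. Compound 4 is therefore estimated at 55%, with a range from 35% to 75% reflecting the absence of a relevant comparison.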

Compound 4, percent of the compound remaining: 4%
Compound 4: the middle estimate sits 51 percentage points above what was measured; the measured number lies below the stated range.
By their numbers in this assay, from the lowest: compound 4; then compound 3; then compound 1; then compound 2.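

In this assay, (4-carbamoylpiperazin-1-yl)methyl in place of piperidin-3-yl gives a number 51 percentage points lower from compound 1 to compound 4 (beyond the scatter), so with the shared core kept, the read-out is sensitive to the group on this saturated chain carbon, two bonds along the chain from an amine nitrogen. The earlier step, a number 39 percentage points lower from compound 2 to compound 3 (beyond the scatter), lay at a different place, so two separate places in the series now each carry a large step on a single change. No measurement shown here accounts for the lower number at this position.

As far as these compounds go, it remains open which part of the entering group goes with the lower number: the carbamoyl, the piperazine ring or the extra methylene that comes with the (4-carbamoylpiperazin-1-yl)methyl group. A piperazinylmethyl group without the carbamoyl, and a piperidinylmethyl group, each on the core of compound 1, would separate these parts, and an acetyl in place of the carbamoyl would show whether the terminal urea itself matters.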